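A few compounds are considered here, and "the series" means these few. Any claim that something is new, unique, unknown or untested is made for them only; others in the source may bear on it.

Of the compounds shown here, three sharing one core have numbers so far in an ADME assay on HeLa cells (Homo sapiens) for cytotoxicity, read by MTT assay; a higher number here means a weaker inhibitor, a lower number a stronger inhibitor. Compound 1 `COC(=O)CNC(=O)CCC(=O)Oc1ccc(C[C@H]2C(=O)OC[C@@H]2Cc2ccc(OC)c(OC)c2)cc1OC` gives 179000 nM, compound 2 `COc1ccc(C[C@H]2COC(=O)[C@@H]2Cc2ccc(OC(=O)CCC(=O)N3CCCC3)c(OC)c2)cc1OC` gives 201000 nM, and compound 3 `COC(=O)[C@H](CC(C)C)NC(=O)CCC(=O)Oc1ccc(C[C@H]2C(=O)OC[C@@H]2Cc2ccc(OC)c(OC)c2)cc1OC` gives 53200 nM. Compound 3 therefore has the lowest number of the three, and it is the starting point here.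

Compound 4 `COc1ccc(C[C@H]2COC(=O)[C@@H]2Cc2ccc(OC(=O)CCC(=O)N3CCCCC3)c(OC)c2)cc1OC` has not yet been measured. It carries piperidin-1-yl in place of (1-(methoxycarbonyl)-3-methylbutyl)amino on a carbonyl carbon.

Within the data shown here, three measured steps bear on this change. The closest is a 3.8-fold lower number from compound 2 to compound 3 (0.58 log units; beyond the scatter), a change at the same carbonyl carbon that brings in (1-(methoxycarbonyl)-3-methylbutyl)amino in place of pyrrolidin-1-yl, the measured group nearest to piperidin-1-yl. A similar size appears in a 3.4-fold lower number from compound 1 to compound 3 (0.53 log units; beyond the scatter), where isobutyl replaces hydrogen on the chain. By contrast, a 1.1-fold higher number from compound 1 to compound 2 (0.05 log units; within the scatter) shows that swapping ((methoxycarbonyl)methyl)amino for pyrrolidin-1-yl makes no clear difference. Compound 4 has no isobutyl group, so its number is expected to return towards those of compound 1 and compound 2, reversing a modest step rather than opening a large one. The expected change is a 3.4-fold higher number from compound 3 to compound 4 (0.53 log units; beyond the scatter). Compound 4 is estimated at 180000 nM, with an expected range of 90000 nM to 350000 nM.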

Compound 4, half-maximal inhibitory concentration: 128000 nM
Beside the measured number, compound 4's estimate is 1.4-fold (0.15 log units) above it, and the stated range covers the measured number.
By their numbers in this assay, from the lowest: compound 3; then compounds 4, 1 and 2 (each within the scatter of the next).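

Replacing (1-(methoxycarbonyl)-3-methylbutyl)amino with piperidin-1-yl on this carbonyl carbon gives a 2.4-fold higher number from compound 3 to compound 4 (0.38 log units; beyond the scatter) in this assay, so the lower number of compound 3 is not kept when this ring takes that place. Changing the ring itself makes no clear difference, with a 1.6-fold lower number from compound 2 to compound 4 (0.20 log units; within the scatter) for piperidin-1-yl in place of pyrrolidin-1-yl, and replacing ((methoxycarbonyl)methyl)amino with piperidin-1-yl likewise gives a 1.4-fold lower number from compound 1 to compound 4 (0.15 log units; within the scatter). Among these four compounds, only compound 3 therefore stands apart from the others, although no other data here bear on the reason for this result.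

The compounds shown do not separate the contributions of the parts of the group in compound 3, so a free carboxylic acid in place of its methyl ester, or a methyl group in place of its isobutyl chain, would test which part goes with the lower number. They also leave open whether a ring carrying a second hetero atom, such as morpholin-4-yl, would behave like piperidin-1-yl on this carbonyl carbon.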